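Replacing 4-methylphenyl with 1,1-dimethylpropyl in compound 2

The source may report more compounds than this note shows. Statements on the series, on what has been measured and on what is new or still open speak of the compounds shown alone.

Compound 1 `O=C(Nc1ccc2nc(NC(=O)C3CCCCC3)sc2c1)c1cccc(Oc2ccccc2)c1`: > 4 ug/mL (a limit)
Compound 2 `Cc1ccc(C(=O)Nc2ccc3nc(NC(=O)C4CCCCC4)sc3c2)cc1`: 5.1 ug/mL
Compound 3 `O=C(Nc1ccc2nc(NC(=O)C3CCCCC3)sc2c1)c1c(F)cccc1C(F)(F)F`: 0.032 ug/mL

These three compounds share one core and were tested in a functional assay on WI-38 VA13 cells (Homo sapiens) for cytotoxicity (a higher number here means that more compound is needed for the effect, a lower number that less compound is needed), for their effect on the cells. The reading for compound 1 is a limit (> 4 ug/mL) and not a number. That leaves two numeric values. Compound 2 has the higher one, and compound 3 at 0.032 ug/mL lies far lower, well beyond the usual scatter.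

Compound 4 `CCC(C)(C)C(=O)Nc1ccc2nc(NC(=O)C3CCCCC3)sc2c1` has not yet been measured in this assay. It differs from compound 2 at one place, with 1,1-dimethylpropyl in place of 4-methylphenyl on a carbonyl carbon. For the measured compounds named here, no measured pair in this set shows this change directly, so the expectation is only loose. The group on this carbonyl differs among the measured compounds, and compound 3 at 0.032 ug/mL shows how far the number can fall from that of compound 2 at 5.1 ug/mL in this series. A moderate move toward a lower number is therefore expected, a little beyond the scatter, and the estimated step is a 2.8-fold lower number from compound 2 to compound 4 (0.45 log units; beyond the scatter). The value expected for compound 4 is 1.8 ug/mL (estimated range 0.2 ug/mL to 10 ug/mL).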

Compound 4, half-maximal effective concentration: 1 ug/mL
For compound 4 the middle estimate is 1.8-fold (0.26 log units) above the measured one, within the range that was stated.
By their numbers in this assay, from the lowest: compound 3; then compound 4; then compound 2.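

In this assay, for the compounds shown here, replacing 4-methylphenyl with 1,1-dimethylpropyl on the carbonyl carbon gives a 5.1-fold lower number from compound 2 to compound 4 (0.71 log units; beyond the scatter), the first direct reading of a single change at this position. It shows that an aromatic ring on this carbonyl is not needed for a lower number, since the entering group has no ring and fewer heavy atoms than the one it replaces. Nor does the presence of a ring decide the order: compound 2 carries one and stands highest of the numeric values, compound 3 also carries one and gives 0.032 ug/mL, and compound 4 has none and gives 1 ug/mL.

Compound 1 adds no numeric value to this order, as its reading is a limit: the limit of > 4 ug/mL in this assay, at which 1 of the 4 values shown sits. Whether the step follows from losing the ring or from the branching of the chain stays open, as the compounds shown include no straight pentyl chain and no cyclohexyl group or amine-bearing chain on this carbonyl, and these numbers alone give no cause for the step.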